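Cyclohexyl for 2,4-dichlorobenzyl on the amide

This account rests on a few compounds, and the source may have more. Where it says the series, first, only, none or still open, it means among the compounds named here.

Of the compounds shown here, two sharing one core have been tested in a functional assay on HCT-116 cells (Homo sapiens) for cytotoxicity, read by MTT assay, with a stated time of 72 h; on this read-out lower numbers stand for stronger inhibition and higher numbers for weaker inhibition. Compound 1 (`Nc1cccc(Nc2c(C(=O)NCc3ccc(F)cc3)nc(Br)c3cccnc23)c1`) gives only a limit, > 10000 nM. Among the compounds with values here, compound 2 (`N[C@H]1CC[C@H](Nc2c(C(=O)NCc3ccc(Cl)cc3Cl)nc(Br)c3cccnc23)CC1`) gives 6000 nM, the only actual number so far.

Compound 3 (`N[C@H]1CC[C@H](Nc2c(C(=O)NC3CCCCC3)nc(Br)c3cccnc23)CC1`) keeps the core and the side chain of compound 2 and differs at one place: cyclohexyl in place of 2,4-dichlorobenzyl on an amide-type nitrogen. In short, cyclohexyl stands in place of 2,4-dichlorobenzyl on an amide-type nitrogen. Within the data shown here, no measured pair isolates this change, so the size of the step remains a matter of expectation. With compound 2 at 6000 nM as the sole anchor, a small move in this assay towards weaker inhibition is expected, perhaps none beyond the scatter. The expected step is a 1.5-fold higher number from compound 2 to compound 3 (0.18 log units; within the scatter). For compound 3 the estimated value is 9000 nM, with an expected range of 3000 nM to 25000 nM.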

Compound 3, half-maximal inhibitory concentration: > 10000 nM
Compound 3: no number, only a limit (the forecaster's own chance of this, stated with the estimate: 45%); middle value at least 1.1-fold (0.04 log units) from the limit.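

In this assay compound 3 gives only a limit, > 10000 nM. Within the data shown here, this is the first pair that isolates the group on an amide-type nitrogen, and cyclohexyl in place of 2,4-dichlorobenzyl gives an at least 1.6-fold higher number from compound 2 to compound 3 (0.22 log units; that floor lies within the scatter), so the swap brings no gain at this position. The floor does not show a loss beyond the scatter, and the true size of the step cannot be read, with compound 3 sitting at the ceiling of the read-out: the limit of > 10000 nM in this assay, at which 2 of the 3 values shown sit.

Open, from the compounds shown here alone, is how a plain benzyl or a 4-chlorobenzyl on the same nitrogen would read against compound 2, and so whether the aromatic ring or the chlorines matter more. Also open, going by these compounds, is whether a longer chain or an amine in this place would bring a number below the limit.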